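Permeability notes: compound 3 to compound 4

A few compounds are considered here, and "the series" means these few. Any claim that something is new, unique, unknown or untested is made for them only; others in the source may bear on it.

Measured in an ADME assay for permeability, using PAMPA, with a stated time of 30 min, at pH 7.4; a lower number here means that the compound crosses the layer more slowly, a higher number that the compound crosses the layer faster:
compound 1 `Fc1ccc(Oc2ccc3c(NCCCNCc4ccco4)ccnc3c2)cc1` gives 317 10^-6 cm/s
compound 2 `COc1ccc(-c2ccc3c(NCCCNCc4ccco4)ccnc3c2)cc1` gives 237 10^-6 cm/s
compound 3 `COc1ccc(Oc2ccc3c(NCCCNCc4ccco4)ccnc3c2)cc1` gives 317 10^-6 cm/s

Compound 3 stands level with compound 1 at the digits printed, the two together the highest of the three numbers in this assay; the step from compound 1 to compound 3 is no change at the digits printed from compound 1 to compound 3 (within the scatter), and from compound 2 to compound 3 it is a 1.3-fold higher number from compound 2 to compound 3 (0.13 log units; within the scatter).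

Compound 4 `Fc1ccc(Cc2ccc3c(NCCCNCc4ccco4)ccnc3c2)cc1` differs from compound 3 as follows: 4-fluorobenzyl in place of 4-methoxyphenoxy on an aromatic carbon. Both measured steps bear on this change, one swapping methoxy for fluoro, the other swapping phenoxy for phenyl, and neither moved this assay beyond the scatter. No step beyond the scatter is therefore expected for compound 4 in this assay, the expected step being a 1.1-fold lower number from compound 3 to compound 4 (0.02 log units; within the scatter). Compound 4 is estimated at 300 10^-6 cm/s, with a range of 190 10^-6 cm/s to 470 10^-6 cm/s.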

Compound 4, apparent permeability: 23 10^-6 cm/s
Compound 4: the middle estimate sits 13-fold (1.12 log units) above what was measured, outside the stated range (below it).
By their numbers in this assay, from the lowest: compound 4; then compounds 2, 1 and 3 (each within the scatter of the next).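

In this assay the phenoxy and phenyl groups at this position stay within the scatter of one another, but 4-fluorobenzyl breaks from all three earlier compounds: a 14-fold lower number from compound 3 to compound 4 (1.14 log units; beyond the scatter) and a 10-fold lower number from compound 2 to compound 4 (1.01 log units; beyond the scatter) and also a 14-fold lower number from compound 1 to compound 4 (1.14 log units; beyond the scatter) in the same direction. For the compounds shown here, the fluoro is common to compound 1 and compound 4, so this step goes with the benzyl link itself, which the earlier steps gave no sign of. Nothing measured here gives a reason for this step.

As far as these compounds go, whether the step belongs to the benzyl link alone remains open. A 4-methoxybenzyl group, or an amine or carbonyl as the link, would test this.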